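This account rests on a few compounds, and the source may have more. Where it says the series, first, only, none or still open, it means among the compounds named here.

Of the compounds shown here, two with a shared core have been measured in a functional assay for inhibition of sodium/hydrogen exchanger (Oryctolagus cuniculus); a higher number here means a weaker inhibitor, a lower number a stronger inhibitor. Compound 1 `Cc1cc(F)c(S(C)(=O)=O)cc1C(=O)N=C(N)N` gives 44 nM. Among the measured compounds shown here, compound 2 `Cc1cc(O)c(S(C)(=O)=O)cc1C(=O)N=C(N)N` gives 220 nM, the highest of the two numbers, and the only measured step, a 5.0-fold higher number from compound 1 to compound 2 (0.70 log units; beyond the scatter), separates it from compound 1.

Compound 3 `COc1cc(C)c(C(=O)N=C(N)N)cc1S(C)(=O)=O` is not yet measured. It differs from compound 2 by methyl in place of hydrogen on an oxygen on an aromatic ring, so the same difference read one bond further out is hydroxy to methoxy. For the measured compounds named here, no measured step bears directly on this change; the one measured step concerns a different replacement at the same aromatic carbon and cannot be carried over. Going by the values given here, with no precedent, the expected change from compound 2 to compound 3 is a 1.5-fold lower number from compound 2 to compound 3 (0.17 log units; within the scatter), a step whose direction is open and may well stay within the scatter. Compound 3 is estimated at 150 nM, within the range 50 nM to 450 nM.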

Compound 3, half-maximal inhibitory concentration: 16 nM
Compound 3: middle estimate off by 9.4-fold (0.97 log units), on the high side; the measured number lies below the stated range.
By their numbers in this assay, from the lowest: compound 3; then compound 1; then compound 2.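

In this assay, putting a methyl on the oxygen of the hydroxy group gives a 14-fold lower number from compound 2 to compound 3 (1.14 log units; beyond the scatter), so a single added carbon on this oxygen is enough to turn the weakest inhibitor of the three into the strongest. Methoxy also outperforms fluoro at the same aromatic carbon, with a 2.8-fold lower number from compound 1 to compound 3 (0.44 log units; beyond the scatter), which shows that the gain goes beyond recovering what was lost on replacing fluoro with hydroxy, and that the order at this carbon runs methoxy, then fluoro, then hydroxy. No measurement at hand accounts for these differences.

From the compounds shown here alone, whether a longer chain on the oxygen, such as ethoxy or propoxy, would lower the number further remains open. So does whether an oxygen is needed at this carbon at all, which an amine or a plain ethyl group there could test.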